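Swapping a pyrazole for a triazole on the benzyl arm

The source may hold more compounds than are shown below. What is called first, only, known or untested is meant among the compounds shown, and "the series" means these compounds.

Three urea compounds built on a shared core have been tested in an assay on microsomes from intestine for inhibition of acyl-CoA:cholesterol acyltransferase (Oryctolagus cuniculus); a higher number here means a weaker inhibitor, a lower number a stronger inhibitor. Compound 1 `O=C(Nc1c(F)cc(F)cc1F)N(Cc1ccc(-c2cccs2)cc1)C1CCCCCC1` gives 18 nM in this assay. Compound 2 `O=C(Nc1c(F)cc(F)cc1F)N(Cc1cccc(-c2cc[nH]n2)c1)C1CCCCCC1` gives 22 nM. Going by the values given here, compound 3 `Cc1cc(C)c(NC(=O)N(Cc2ccc(-n3cccn3)cc2)C2CCCCCC2)c(C)c1` gives 70 nM, the highest number of the three; its gap to compound 2 and its gap to compound 1 both lie beyond the usual scatter, so compound 3 is the weakest inhibitor among the compounds measured so far.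

Compound 4 `Cc1cc(C)c(NC(=O)N(Cc2ccc(-n3ccnn3)cc2)C2CCCCCC2)c(C)c1` has not yet been measured. It differs from compound 3 in one place: 1H-1,2,3-triazol-1-yl in place of 1H-pyrazol-1-yl on an aromatic carbon. No measured pair shows this same change, so there is no direct precedent among these compounds. Among the compounds with values here, because compound 3 stands at 70 nM, the starting point is already the weakest of the set, and the change keeps the five-membered aromatic ring attached in the same place with only one more ring nitrogen. The step of a 1.2-fold higher number from compound 3 to compound 4 (0.08 log units; within the scatter) is therefore expected to be small, most likely within the usual scatter, with a slight lean toward a higher number. Compound 4 is expected to give 85 nM in this assay, with a range from 30 nM to 240 nM.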

Compound 4, half-maximal inhibitory concentration: 42 nM
Estimate against measurement, compound 4: 2.0-fold (0.31 log units) above; measured number inside the range.
By their numbers in this assay, from the lowest: compounds 1, 2, 4 and 3 (each within the scatter of the next, the first and the last beyond it).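

This is the first step among the compounds shown that changes a single place. In this assay the exchange of 1H-pyrazol-1-yl for 1H-1,2,3-triazol-1-yl on an aromatic carbon para to a large group gives a 1.7-fold lower number from compound 3 to compound 4 (0.22 log units; within the scatter) and so gives no basis for placing the two compounds in order. At this position, a five-membered aromatic ring with 3 hetero atoms and 3 hydrogen-bond acceptors therefore cannot be told apart from one with 2 hetero atoms and 2 hydrogen-bond acceptors, although this rests on a single pair, and no evidence is available that bears on why the two compounds read alike.

The compounds shown leave open whether a tetrazole or an imidazole attached at the same place would also stay within the scatter of compound 3, or whether a morpholine or a plain methoxy group would mark a limit to what this position accepts. They also leave open whether the same exchange would read the same way when paired with the fluorinated aryl group on the urea of compound 1.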